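A few compounds are considered here, and "the series" means these few. Any claim that something is new, unique, unknown or untested is made for them only; others in the source may bear on it.

In a functional assay on HepG2 cells (Homo sapiens) for inhibition, read by ATP content, with a stated time of 72 h (on this read-out higher numbers stand for weaker inhibition and lower numbers for stronger inhibition), compound 1 (`CCN(CC)c1ccc(NC(=O)CCCCCCC(=O)NO)cc1`) gives 2400 nM and compound 2 (`CC(C)(C)OC(=O)N1CCC(NC(=O)c2ccc(NC(=O)CCCCCCC(=O)NO)cc2)CC1`) gives 150000 nM as the higher of the two numbers, beyond the scatter from compound 1. Compound 3 (`O=C(CCCCCCC(=O)Nc1ccc(C(=O)NC2CCNCC2)cc1)NO`) differs from compound 2 by hydrogen in place of tert-butoxycarbonyl on an amine nitrogen in a ring with hydrogen in place of tert-butoxycarbonyl on an amine nitrogen in a ring. Among the measured compounds shown here, no measured pair shows this change on its own, so the expectation is uncertain. A lower number is expected, with an estimated 6.0-fold lower number from compound 2 to compound 3 (0.78 log units; beyond the scatter) as a step beyond the scatter. The estimated value for compound 3 is 25000 nM (expected range 4000 nM to 120000 nM).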

Compound 3, half-maximal inhibitory concentration: 23000 nM
Beside the measured number, compound 3's estimate is 1.1-fold (0.04 log units) above it; the measured number falls inside the stated range.
By their numbers in this assay, from the lowest: compound 1; then compound 3; then compound 2.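

In this assay, hydrogen in place of tert-butoxycarbonyl on the amine nitrogen in the ring gives a 6.5-fold lower number from compound 2 to compound 3 (0.81 log units; beyond the scatter), so the group on this nitrogen moves the number beyond the scatter. Even with hydrogen there, (piperidin-4-yl)carbamoyl in place of diethylamino on an aromatic carbon gives a 9.6-fold higher number from compound 1 to compound 3 (0.98 log units; beyond the scatter). Nothing available accounts for either step. Still open, going by these compounds, is how a group smaller than tert-butoxycarbonyl on this nitrogen, such as methyl or acetyl, would read.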